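Replacing pyrrolidin-1-yl in compound 3

A few compounds are considered here, and "the series" means these few. Any claim that something is new, unique, unknown or untested is made for them only; others in the source may bear on it.

Of the compounds shown here, three have been measured in a functional assay on MIA PaCa-2 cells (Homo sapiens) for inhibition, read by MTT assay, with a stated time of 48 h, tested at 10 uM; a lower number here means less inhibition of growth, a higher number more inhibition of growth at the concentration tested. Compound 1 (`Cc1cc(=O)c2c(O)cc(OCc3ccccc3)c([C@H]3CCN(C)C[C@H]3O)c2o1`) gives 14%, compound 2 (`Cc1cc(=O)c2c(O)cc(OCc3ccco3)c([C@H]3CCN(C)C[C@H]3O)c2o1`) gives 7%, and compound 3 (`Cc1cc(=O)c2c(O)c(CN3CCCC3)c(O)c([C@H]3CCN(C)C[C@H]3O)c2o1`) gives 28%. That last number is the highest of the three and stands beyond the scatter from both others.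

Compound 4 (`CCOC(=O)N1CCN(Cc2c(O)c([C@H]3CCN(C)C[C@H]3O)c3oc(C)cc(=O)c3c2O)CC1`) has not yet been measured. It departs from compound 3 in a single place: 4-(ethoxycarbonyl)piperazin-1-yl in place of pyrrolidin-1-yl on a saturated chain carbon bound to an aromatic carbon. The 4-(ethoxycarbonyl)piperazin-1-yl group takes the place of pyrrolidin-1-yl on a saturated chain carbon bound to an aromatic carbon.

Among the measured compounds shown here, the only single-place step available is a number 7 percentage points lower from compound 1 to compound 2 (within the scatter). That change lies elsewhere, on a saturated chain carbon bound to an oxygen on an aromatic ring, and offers only weak guidance. For the measured compounds named here, no measured step covers the place that changes here, and the expectation stays uncertain.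

No step beyond the scatter is expected, and the estimated step is a number 6 percentage points lower from compound 3 to compound 4 (within the scatter). For compound 4 the estimated value is 22%, with an expected range from 7% to 38%.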

Compound 4, percent growth inhibition at one concentration: 4%
Beside the measured number, compound 4's estimate is 18 percentage points above it, and the stated range ends above it.
By their numbers in this assay, from the lowest: compounds 4, 2 and 1 (each within the scatter of the next); then compound 3.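

In this assay the group on a saturated chain carbon bound to an aromatic carbon proves to matter: 4-(ethoxycarbonyl)piperazin-1-yl in place of pyrrolidin-1-yl gives a number 24 percentage points lower from compound 3 to compound 4 (beyond the scatter) at the concentration tested. Among the compounds shown here, this is the first single-place change to move the number beyond the scatter, and the measured number falls rather than rises. Nothing available bears on why the number falls.

The swap alters the ring size, the ring's second nitrogen and the ethoxycarbonyl group together, so the compounds shown leave open which of these parts goes with the lower number. Piperidin-1-yl, morpholin-4-yl or unsubstituted piperazin-1-yl on the same carbon would separate them, and a dimethylamino group would show what an open-chain amine does there.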